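This account rests on a few compounds, and the source may have more. Where it says the series, first, only, none or still open, it means among the compounds named here.

Measured in a functional assay on RAW264.7 cells (Mus musculus) for inhibition, read by Griess assay, with stated times of 1 h and 24 h; on this read-out higher numbers stand for weaker inhibition and lower numbers for stronger inhibition:

- compound 1 `C=CCOc1ccccc1C1CC(=O)c2ccccc2O1`: 37800 nM
- compound 2 `O=C1CC(c2ccccc2O)Oc2ccccc21`: 71300 nM
- compound 3 `O=C1CC(c2ccccc2OCc2cccc(F)c2)Oc2ccccc21`: 15600 nM

Of these three, compound 3 has the lowest number, at 15600 nM. The gaps to the other two lie beyond the scatter: a 2.4-fold lower number from compound 1 to compound 3 (0.38 log units; beyond the scatter), and a 4.6-fold lower number from compound 2 to compound 3 (0.66 log units; beyond the scatter).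

The next compound is compound 4 `COCOc1ccccc1C1CC(=O)c2ccccc2O1`, which differs from compound 3 by methoxy in place of 3-fluorophenyl on a saturated chain carbon bound to an oxygen on an aromatic ring. This puts methoxy in place of 3-fluorophenyl on a saturated chain carbon bound to an oxygen on an aromatic ring. Cut one bond further out, the same difference reads 3-fluorobenzyl to methoxymethyl.

Within the data shown here, two measured steps bear most directly on this change, as both involve the 3-fluorobenzyl group that compound 4 lacks: a 2.4-fold lower number from compound 1 to compound 3 (0.38 log units; beyond the scatter), and a 4.6-fold lower number from compound 2 to compound 3 (0.66 log units; beyond the scatter). Both are modest. The third step, a 1.9-fold higher number from compound 1 to compound 2 (0.28 log units; within the scatter), stays within the scatter, so allyl and hydrogen on that oxygen are not told apart in this assay. Methoxymethyl has not been measured at this place, but it is expected to fall with these two rather than with compound 3. The expected change is a modest one, a 2.7-fold higher number from compound 3 to compound 4 (0.43 log units; beyond the scatter). For compound 4 the estimated value is 42000 nM, with an expected range of 20000 nM to 85000 nM.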

Compound 4, half-maximal inhibitory concentration: 32600 nM
For compound 4 the middle estimate is 1.3-fold (0.11 log units) above the measured one; measured number inside the range.
By their numbers in this assay, from the lowest: compound 3; then compounds 4, 1 and 2 (each within the scatter of the next, the first and the last beyond it).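

In this assay, replacing 3-fluorophenyl with methoxy gives a 2.1-fold higher number from compound 3 to compound 4 (0.32 log units; beyond the scatter), so the methoxymethyl group on the oxygen does not match the 3-fluorobenzyl group, although the step is modest. Methoxymethyl is nonetheless told apart from hydrogen at this place, with a 2.2-fold lower number from compound 2 to compound 4 (0.34 log units; beyond the scatter), a separation that allyl did not give in a 1.9-fold higher number from compound 1 to compound 2 (0.28 log units; within the scatter). Methoxymethyl and allyl themselves cannot be separated, as a 1.2-fold lower number from compound 1 to compound 4 (0.06 log units; within the scatter) shows, which leaves compound 3, with its 3-fluorobenzyl group, as the only compound here beyond the scatter of all the others.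

Nothing available explains these differences in terms of any property of the groups. The compounds shown leave open whether the advantage of compound 3 comes from the aromatic ring or from its fluorine, a question that a plain benzyl group on this oxygen would address. They also leave open how a longer alkyl chain or a chain ending in an amine would compare with the 3-fluorobenzyl group.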